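Tetrazole Moved Onto a Methoxy Linker

The source may report more compounds than this note shows. Statements on the series, on what has been measured and on what is new or still open speak of the compounds shown alone.

Among the measured compounds shown here, compound 1 `O=C(/C=C/c1cccc(/C=C/c2ccc3ccccc3n2)c1)c1cc(-c2nn[nH]n2)ccc1O` and compound 2 `O=C(O)c1cccc(C(=O)/C=C/c2cccc(/C=C/c3ccc4ccccc4n3)c2)c1O` are the two compounds measured so far. In an assay on membranes from lung (Cavia porcellus) for displacement of a labelled ligand from cysteinyl leukotriene receptor (Homo sapiens) (on this read-out lower numbers stand for tighter binding and higher numbers for weaker binding), compound 1 gives 21 nM, the lower of the two numbers, and compound 2 gives 26 nM; the two values lie within the scatter of each other, so neither can be placed above the other. Compound 3 `O=C(/C=C/c1cccc(/C=C/c2ccc3ccccc3n2)c1)c1cc(OCc2nn[nH]n2)ccc1O` has not been measured. It differs from compound 1 in one place: (2H-tetrazol-5-yl)methoxy in place of 2H-tetrazol-5-yl on an aromatic carbon. For the measured compounds named here, no step between measured compounds shows what such an insertion does here, so the expectation rests on compound 1 alone. A step from compound 1 to compound 3 of modest size toward a higher number, that is toward weaker binding, is expected, a 2.9-fold higher number from compound 1 to compound 3 (0.46 log units; beyond the scatter), though a result within the scatter of compound 1 cannot be excluded. For compound 3 in this assay an estimated 60 nM is expected, with a range from 15 nM to 250 nM.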

Compound 3, dissociation constant: 45 nM
For compound 3 the middle estimate is 1.3-fold (0.12 log units) above the measured one, and the stated range covers the measured number.
By their numbers in this assay, from the lowest: compounds 1, 2 and 3 (each within the scatter of the next, the first and the last beyond it).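

Placing (2H-tetrazol-5-yl)methoxy in place of 2H-tetrazol-5-yl on this aromatic carbon, para to a hydroxy group, gives the first change that can be read at this position. In this assay the change is a 2.1-fold higher number from compound 1 to compound 3 (0.33 log units; beyond the scatter) and is modest in size, so the position accepts the tetrazole on a methoxy linker at a measurable but limited cost in binding. The data shown offer no measured basis for explaining this cost.

Still open, as far as these compounds go, is whether the step follows from the added linker or depends on the tetrazole it carries, a question that a carboxylic acid on the same methoxy linker or a tetrazole on a longer chain could address. Also open, from the compounds shown here alone, is whether the same step would appear if a methoxy group stood in place of the hydroxy group.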